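A few compounds are considered here, and "the series" means these few. Any claim that something is new, unique, unknown or untested is made for them only; others in the source may bear on it.

Measured in a functional assay on MCF7 cells (Homo sapiens) for antiproliferative activity, read by MTT assay, with a stated time of 72 h; on this read-out lower numbers stand for stronger inhibition and higher numbers for weaker inhibition:

Compound 1 `CC1=CCC2C(CC[C@@]2(C)O)C(C)(C)C1CC[C@@H]1[C@@]2(C)CC[C@@H](O)C(C)(C)O[C@@H]2CC[C@]1(C)O`: 44500 nM
Compound 2 `CC1=CC[C@H]2[C@H](CC[C@]2(C)O)C(C)(C)[C@@H]1CC[C@H]1[C@]2(C)CC[C@H](OC(=O)CCC(=O)O)C(C)(C)O[C@H]2CC[C@@]1(C)O`: > 50000 nM (a limit)

Compound 2 gives no number in this assay. Its entry is a limit: the limit of > 50000 nM in this assay, at which 1 of the 2 values shown sits. Compound 3 `CC1=CC[C@H]2[C@H](CC[C@]2(C)O)C(C)(C)[C@@H]1CC[C@H]1[C@]2(C)CC[C@H](OC(=O)c3ccncc3)C(C)(C)O[C@H]2CC[C@@]1(C)O` carries pyridin-4-yl in place of 2-carboxyethyl on a carbonyl carbon, and the count of that change reads (pyridin-4-yl in place of 2-carboxyethyl on a carbonyl carbon). Among the measured compounds shown here, no measured step covers this change, so any expectation rests on little. The shared core gives only weak inhibition in compound 1, at 44500 nM, so a large gain is not expected from this exchange alone. An estimated step of an at least 1.7-fold lower number from compound 2 to compound 3 (0.25 log units; that floor lies within the scatter) is expected, modest in size and toward stronger inhibition, and a reading that again ends at the limit would not surprise. For compound 3 the estimated value is 28000 nM, with an expected range of 10000 nM to 60000 nM.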

Compound 3, half-maximal inhibitory concentration: 25300 nM
The estimate for compound 3 lay 1.1-fold (0.04 log units) above the measured number, within the range that was stated.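

With pyridin-4-yl on the carbonyl carbon, compound 3 gives 25300 nM in this assay, so this ester position can carry a ring and still return a number. Compound 2, with 2-carboxyethyl at the same place, has a limit and not a number: the limit of > 50000 nM in this assay, at which 1 of the 3 values shown sits. The change therefore reads only as an at least 1.9-fold lower number from compound 2 to compound 3 (0.29 log units; that floor lies within the scatter), which fixes a floor and not a size, and it does not establish a change beyond the usual scatter.

The compounds shown do not tell whether the outcome comes from the arrival of pyridin-4-yl or from the departure of 2-carboxyethyl. From the compounds shown here alone, a phenyl ring or a short alkyl chain on the same carbonyl carbon would bear on that question, and how far the true step reaches remains open.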